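Varying the aryl group: a carboxylic acid replaces two fluorines

A few compounds are considered here, and "the series" means these few. Any claim that something is new, unique, unknown or untested is made for them only; others in the source may bear on it.

Of the compounds shown here, three sharing one core have been measured in an ADME assay on microsomes from liver (Homo sapiens) for metabolic stability; a higher number here means that the compound lasts longer, a lower number that the compound disappears faster. Compound 1 `COc1ccc(C2=Nc3c(C(C)(C)C)nn(CCCO)c3C(=O)NC2)cc1-c1ccc(F)cc1F` gives 2 h, and compound 2 `COc1ccc(-c2cc(C3=Nc4c(C(C)(C)C)nn(CCCO)c4C(=O)NC3)ccc2OC)c(OC)c1` gives 2 h; together these are the highest of the three numbers. Compound 3 `COc1ccc(C2=Nc3c(C(C)(C)C)nn(CCCO)c3C(=O)NC2)cc1-c1ccccc1SC` gives 0.85 h.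

Compound 4 `COc1ccc(C2=Nc3c(C(C)(C)C)nn(CCCO)c3C(=O)NC2)cc1-c1ccc(C(=O)O)cc1` has not yet been measured in this assay. It differs from compound 1 in one place: 4-carboxyphenyl in place of 2,4-difluorophenyl on an aromatic carbon

Two measured steps start from the same 2,4-difluorophenyl group. The step of no change at the digits printed from compound 1 to compound 2 (within the scatter) shows one replacement leaving the half-life unchanged, while a 2.4-fold lower number from compound 1 to compound 3 (0.37 log units; beyond the scatter) shows another lowering it modestly. Neither step puts a carboxylic acid on the ring, so the expectation for compound 4 rests on this limited picture: a step of about a 1.3-fold higher number from compound 1 to compound 4 (0.10 log units; within the scatter) is expected, most likely within the scatter or slightly upward. Compound 4 is therefore estimated to give 2.5 h in this assay, within a range from 1.2 h to 6 h.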

Compound 4, half-life: 2 h
The estimate for compound 4 lay 1.3-fold (0.10 log units) above the measured number; measured number inside the range.
By their numbers in this assay, from the lowest: compound 3; then compounds 1, 2 and 4 (each within the scatter of the next).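

In this assay, the 4-carboxyphenyl group, which brings a hydrogen-bond donor and acceptor that the 2,4-difluorophenyl group lacks, sits at this position with no change at the digits printed from compound 1 to compound 4 (within the scatter). The comparison with the 2,4-dimethoxyphenyl group likewise gives no change at the digits printed from compound 2 to compound 4 (within the scatter), while the comparison with the 2-(methylsulfanyl)phenyl group gives a 2.4-fold higher number from compound 3 to compound 4 (0.37 log units; beyond the scatter), so among these four compounds only compound 3 stands apart. No supporting measurement is available to explain why these quite different aryl groups give such similar half-lives.

Going by these compounds, it remains open whether a basic amine on the ring, as in a 4-aminophenyl group, would fit the same picture. A 2-methoxyphenyl group, with oxygen in place of the sulfur of compound 3, could show whether that sulfur atom is what separates compound 3 from the rest.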